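A Larger Ring on the Chain of Compound 3

A few compounds are considered here, and "the series" means these few. Any claim that something is new, unique, unknown or untested is made for them only; others in the source may bear on it.

In a functional assay on HCT-116 cells (Homo sapiens) for antiproliferative activity, read by sulforhodamine B assay, with a stated time of 72 h (on this read-out lower numbers stand for stronger inhibition and higher numbers for weaker inhibition), compound 1 `COc1ncc(-c2ccc3c(c2)N(CCC(=O)N2CCOCC2)C(=O)CO3)cc1NS(=O)(=O)c1ccc(F)cc1F` gives 3180 nM and compound 2 `COc1ncc(-c2ccc3c(c2)N(Cc2ccncc2)C(=O)CO3)cc1NS(=O)(=O)c1ccc(F)cc1F` gives 2220 nM. Compound 3 `CCCCS(=O)(=O)Nc1cc(-c2ccc3c(c2)N(CCCn2cccn2)C(=O)CO3)cnc1OC` gives 33600 nM, the highest of the three numbers and beyond the scatter from both of the others. Compound 3 also differs from those two in more than one part of the structure, so their values say little about it directly.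

Compound 4 `CCCCS(=O)(=O)Nc1cc(-c2ccc3c(c2)N(CCCn2ccccc2=O)C(=O)CO3)cnc1OC` departs from compound 3 in one place only: a group of 7 heavy atoms (5 carbon, 1 nitrogen, 1 oxygen; one six-membered aromatic ring with 1 hetero atom) in place of a group of 5 heavy atoms (3 carbon, 2 nitrogen; one five-membered aromatic ring with 2 hetero atoms), on a saturated chain carbon, three bonds along the chain from an amide-type nitrogen in a ring.

Just one measured step concerns a group carried on the same amide-type nitrogen in a ring: a 1.4-fold lower number from compound 1 to compound 2 (0.16 log units; within the scatter). That step lies within the scatter. It was measured with a different group elsewhere on the shared core, and at a different point on the chain, so it bears on the present change only loosely. For the measured compounds named here, no measured step tests the loss of the 1H-pyrazol-1-yl group itself.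

Going by the values given here, with only this evidence, no change beyond the scatter is expected in this assay. The estimated size of the change is a 1.3-fold lower number from compound 3 to compound 4 (0.11 log units; within the scatter). For compound 4 the expected value is 26000 nM, with an estimated range from 9000 nM to 75000 nM.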

Compound 4, half-maximal inhibitory concentration: 42600 nM
For compound 4 the middle estimate is 1.6-fold (0.21 log units) below the measured one; measured number inside the range.
By their numbers in this assay, from the lowest: compounds 2 and 1 (each within the scatter of the next); then compounds 3 and 4 (each within the scatter of the next).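

In this assay, replacing the 1H-pyrazol-1-yl group with the larger six-membered aromatic ring with 1 hetero atom and a double bond outside it, on a saturated chain carbon, three bonds along the chain from an amide-type nitrogen in a ring, gives a 1.3-fold higher number from compound 3 to compound 4 (0.10 log units; within the scatter). This is the first step shown that exchanges one ring for another at this place, and it shows that ring size, the number of ring nitrogens and the added oxygen can all differ while the two numbers stay within the scatter of each other, with the count of hydrogen-bond donors and acceptors the same for both groups. Nothing available explains this result, and no measurement on these compounds separates the contributions of the individual differences between the two groups.

From the compounds shown here alone, it remains open whether a group at the end of this chain matters at all, since a chain ending in a primary amine, a carboxylic acid or a simple methyl group would test this more sharply than one aromatic ring against another. Going by these compounds, it is also open whether the same exchange would give a comparable step on a core carrying the difluorophenyl sulfonamide of compounds 1 and 2 in place of the butyl chain.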